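Benzylidene hydrazones as glucose-6-phosphatase inhibitors: a methoxy step

This account rests on a few compounds, and the source may have more. Where it says the series, first, only, none or still open, it means among the compounds named here.

The series shares a dibenzyl hydrazone core. Among the compounds with values here, compound 1, `C(=N/N(Cc1ccccc1)Cc1ccccc1)\c1ccccc1`, carries an unsubstituted phenyl on the imine carbon; in an assay on liver (Sus scrofa) for inhibition of glucose-6-phosphatase catalytic subunit 1 (Homo sapiens), using microsomes (a higher number here means a weaker inhibitor, a lower number a stronger inhibitor), compound 1 gives 1500 nM, the only numerical value in the set so far. Compound 2, `COc1ccc2c(c1)CCC/C2=N\N(Cc1ccccc1)Cc1ccccc1`, replaces that phenyl by a fused bicyclic ketone-derived unit with a methoxy group; in this assay compound 2 reaches only a limit, > 50000 nM, and no number. Thus (the limit of > 50000 nM in this assay, at which 1 of the 2 values shown sits), and compound 1 stands alone as the single measured potency, with nothing above or below it to place it against.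

Compound 3, `COc1ccc(/C=N/N(Cc2ccccc2)Cc2ccccc2)cc1`, is the direct methoxy analogue of compound 1. The change is methoxy in place of hydrogen on an aromatic carbon, para to a large group. Within the data shown here, no measured pair in the set differs in exactly this one place, so no step size is on record. Compound 2 differs from compound 1 in more than one place, so its limit says nothing about the methoxy alone. The step from compound 1 to compound 3 is expected to be small, a 1.7-fold higher number from compound 1 to compound 3 (0.22 log units; within the scatter), and likely within the usual scatter or slightly weakening. Compound 3 is therefore estimated at 2500 nM, within 800 nM to 8000 nM.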

Compound 3, half-maximal inhibitory concentration: 220 nM
Compound 3: the middle estimate sits 11-fold (1.06 log units) above what was measured; the measured number lies below the stated range.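

In this assay, within the data shown here, the change from phenyl to 4-methoxyphenyl gives the first readable step for the series: a 6.8-fold lower number from compound 1 to compound 3 (0.83 log units; beyond the scatter). This shows that on the aromatic ring of compound 1, the position para to a large group accepts methoxy in place of hydrogen, and that the change gives a stronger inhibitor rather than a loss of activity. Compound 2 also carries a methoxy group, but it gives > 50000 nM, a limit and not a number, and it differs from compound 1 in more than one place, so it adds nothing to this step, and nothing measured here accounts for the gain.

On these data alone, the series still rests on one substituent at one position, so it remains open whether the gain is specific to methoxy or would also appear with hydroxyl, ethoxy, a chlorine atom or a dimethylamino group in the same place. Also open, as far as these compounds go, is whether methoxy gives a similar step at other positions on this ring, or on the phenyl rings of the two benzyl groups of the shared core.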